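A few compounds are considered here, and "the series" means these few. Any claim that something is new, unique, unknown or untested is made for them only; others in the source may bear on it.

Measured compounds in a functional assay on SK-OV-3 cells (Homo sapiens) for inhibition, read by sulforhodamine B assay, with a stated time of 48 h; on this read-out higher numbers stand for weaker inhibition of growth and lower numbers for stronger inhibition of growth:
compound 1, `Nc1cc(N)c2nc(-c3ccccc3)c(NCc3ccc(Cl)c(Cl)c3)nc2c1`, gives 36300 nM
compound 2, `Nc1cc(N)c2nc(-c3ccccc3)c(Sc3ccc(F)cc3)nc2c1`, gives 31600 nM
compound 3, `COc1ccc(CNc2nc3cc(N)cc(N)c3nc2-c2ccccc2)cc1OC`, gives 46800 nM

Compound 3 carries the highest of the three numbers, but its gap to compound 1 and its gap to compound 2 are both within the scatter, so no order among the three can be read from these values. Going by the values given here, the one step between measured compounds that differ in a single place, a 1.3-fold higher number from compound 1 to compound 3 (0.11 log units; within the scatter), also lies within the scatter.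

Compound 4, `Nc1cc(N)c2nc(-c3ccccc3)c(NCc3ccc(F)cc3)nc2c1`, is still to be measured. From compound 3 it differs by 4-fluorophenyl in place of 3,4-dimethoxyphenyl on a saturated chain carbon bound to a nitrogen on an aromatic ring. Among the compounds with values here, the only measured step at this same place, a 1.3-fold higher number from compound 1 to compound 3 (0.11 log units; within the scatter), stayed within the scatter, and compound 2, which also carries a 4-fluorophenyl, gives a value within the scatter of compound 3. Nothing measured therefore points to a step beyond the scatter in this assay in either direction, and the expected step is a 1.3-fold lower number from compound 3 to compound 4 (0.11 log units; within the scatter). Compound 4 is estimated at 36000 nM, within 15000 nM to 85000 nM.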

Compound 4, concentration for total growth inhibition: 26300 nM
Estimate against measurement, compound 4: 1.4-fold (0.14 log units) above; measured number inside the range.
By their numbers in this assay, from the lowest: compounds 4, 2, 1 and 3 (each within the scatter of the next).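

In this assay the position on a saturated chain carbon bound to a nitrogen on an aromatic ring now has three groups compared, and both steps to 4-fluorophenyl stay within the scatter: a 1.8-fold lower number from compound 3 to compound 4 (0.25 log units; within the scatter) and a 1.4-fold lower number from compound 1 to compound 4 (0.14 log units; within the scatter). This holds even though 4-fluorophenyl has fewer heavy atoms and fewer hydrogen-bond acceptors than 3,4-dimethoxyphenyl. Going by these compounds alone, the first change at the aromatic carbon, (4-fluorobenzyl)amino in place of (4-fluorophenyl)sulfanyl, also stays within the scatter, with a 1.2-fold lower number from compound 2 to compound 4 (0.08 log units; within the scatter), and no evidence on the cause of these values is available.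

On these data alone, whether a cyclohexyl group, a piperidine or a carboxylic acid in place of the aryl group would move the number beyond the scatter remains open. So does the effect of a longer chain at the same place.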